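The source may report more compounds than this note shows. Statements on the series, on what has been measured and on what is new or still open speak of the compounds shown alone.

Measured compounds:

compound 1 `CCC(=O)N1CCC(CN(C2Cc3cc(C#N)ccc3N(Cc3cncn3C)C2)S(=O)(=O)c2ccccn2)CC1`, 0.5 10^-6 cm/s
compound 2 `Cn1cncc1CN1CC(N(Cc2cccc(-n3cccc3)c2)S(=O)(=O)c2ccccn2)Cc2cc(C#N)ccc21`, 2.3 10^-6 cm/s
compound 3 `Cn1cncc1CN1CC(N(CC2CCN(C(=O)C3CC3)CC2)S(=O)(=O)c2ccccn2)Cc2cc(C#N)ccc21`, 0.5 10^-6 cm/s

In an ADME assay on Caco-2 cells (Homo sapiens) for permeability, in the apical to basolateral direction (a lower number here means that the compound crosses the layer more slowly, a higher number that the compound crosses the layer faster), compound 2 stands highest of the three numbers, with a 4.6-fold higher number from compound 1 to compound 2 (0.66 log units; beyond the scatter) and a 4.6-fold lower number from compound 2 to compound 3 (0.66 log units; beyond the scatter) separating it from its two neighbours. Compound 4 `CC(C)OC(=O)N1CCC(CN(C2Cc3cc(C#N)ccc3N(Cc3cncn3C)C2)S(=O)(=O)c2ccccn2)CC1` differs from compound 2 in one place: 1-(isopropoxycarbonyl)piperidin-4-yl in place of 3-(1H-pyrrol-1-yl)phenyl on a saturated chain carbon bound to a sulfonamide nitrogen. The two steps that bear on this change are a 4.6-fold higher number from compound 1 to compound 2 (0.66 log units; beyond the scatter) and a 4.6-fold lower number from compound 2 to compound 3 (0.66 log units; beyond the scatter), each swapping the same aryl group for an acylated piperidine; no change at the digits printed from compound 1 to compound 3 (within the scatter) shows that the group on the carbonyl carbon mattered little. A comparable downward step is therefore expected for compound 4, namely a 3.3-fold lower number from compound 2 to compound 4 (0.52 log units; beyond the scatter). Compound 4 is accordingly estimated at 0.7 10^-6 cm/s, within 0.3 10^-6 cm/s to 1.6 10^-6 cm/s.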

Compound 4, apparent permeability: 1 10^-6 cm/s
Compound 4: the middle estimate sits 1.4-fold (0.15 log units) below what was measured; the range from low to high includes it.
By their numbers in this assay, from the lowest: compounds 1, 3 and 4 (each within the scatter of the next); then compound 2.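

In this assay, a third acylated piperidine, now carrying isopropoxy on the carbonyl carbon, again falls short of the 3-(1H-pyrrol-1-yl)phenyl group, with a 2.3-fold lower number from compound 2 to compound 4 (0.36 log units; beyond the scatter). Isopropoxy joins ethyl and cyclopropyl on that carbonyl carbon without leaving the scatter, with a 2.0-fold higher number from compound 3 to compound 4 (0.30 log units; within the scatter) and a 2.0-fold higher number from compound 1 to compound 4 (0.30 log units; within the scatter), so all three acylated piperidines shown sit apart from the aryl compound. No supporting measurement explains this gap. The compounds shown leave open whether a piperidine with a free amine nitrogen would behave like these acylated ones, and whether a plain phenyl, without the pyrrole ring, would match compound 2.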